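Ortho-substituted thiourea amides: iodo to trifluoromethyl swap

A few compounds are considered here, and "the series" means these few. Any claim that something is new, unique, unknown or untested is made for them only; others in the source may bear on it.

Compound 1 `NC(=O)c1c(NC(=O)c2ccccc2Cl)sc2c1CCN(C(=S)Nc1ccccc1I)C2` and compound 2 `NC(=O)c1c(NC(=O)c2ccccc2Cl)sc2c1CCN(C(=S)Nc1ccccc1C(F)(F)F)C2` share one core and differ only by trifluoromethyl in place of iodo on an aromatic carbon. In a functional assay on HeLa cells (Homo sapiens) for antiproliferative activity, with a stated time of 24 h (on this read-out lower numbers stand for stronger inhibition and higher numbers for weaker inhibition), compound 1 gives 29000 nM. In this assay compound 2 gives 26700 nM. The step is a 1.1-fold lower number from compound 1 to compound 2 (0.04 log units; within the scatter), so the two compounds read the same within the usual scatter.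

Compound 3 `NC(=O)c1c(NC(=O)c2ccccc2I)sc2c1CCN(C(=S)Nc1ccccc1Cl)C2` has the same atoms as compound 1 joined differently; the difference between the two cores is not broken down here. For compound 3 only a limit is reported: in this assay compound 3 gives > 50000 nM, which is a limit of the assay and not a number. Compound 3 thus sits at the limit of > 50000 nM in this assay, at which 1 of the 3 values shown sits.

Compound 4 `NC(=O)c1c(NC(=O)c2ccccc2C(F)(F)F)sc2c1CCN(C(=S)Nc1ccccc1Cl)C2` is not yet measured and is reached from compound 3 by the same change as before, trifluoromethyl in place of iodo on an aromatic carbon, at a place described in the same words for both pairs.

The expected step is small, since the measured pair moved only by a 1.1-fold lower number from compound 1 to compound 2 (0.04 log units; within the scatter). The expected step from compound 3 is a step that the limit leaves unreadable from compound 3 to compound 4. Compound 4 is therefore expected to give about 60000 nM in this assay, estimated between 30000 nM and 150000 nM, with a good chance that only a limit is reported again.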

Compound 4, half-maximal inhibitory concentration: 46900 nM
The estimate for compound 4 lay 1.3-fold (0.11 log units) above the measured number, and the stated range covers the measured number.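

Working notes on the iodo to trifluoromethyl change: on the core of compound 3, the change gives an at least 1.0-fold lower number from compound 3 to compound 4 (0.02 log units; that floor lies within the scatter) in this assay, and set beside the core of compound 1 the two steps compare as follows: the same change on two cores in this assay, a 1.1-fold lower number (0.04 log units; within the scatter) from compound 1 to compound 2 and an at least 1.0-fold lower number (0.02 log units; that floor lies within the scatter) from compound 3 to compound 4; the limit leaves it open whether they differ

In this assay compound 3 gives > 50000 nM, which is a limit of the assay and not a number. As far as these compounds go, the two pairs are therefore compatible with the change carrying over from one core to the other with no shift beyond the scatter, but they do not show this, since the true size of the step on the core of compound 3 stays unknown and a larger step cannot be excluded.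

Going by these compounds alone, with only two pairs and one swap, no general rule for transferring this change across the series can be drawn, and its behaviour on any further core remains open. Also open, from the compounds shown here alone, is how other groups on the same aromatic carbon, such as a nitrile, an amine or a carboxylic acid, would read in this assay against iodo and trifluoromethyl.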